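Aryl for Alkyl at the Amide Tail of a Calpain Inhibitor

The compounds below may be only part of what the source reports. "The series", "measured", "known", "first", "only" and "open" are said of these compounds alone.

Among the measured compounds shown here, compound 3 `CCCCCCCCNC(=O)C(=O)C(CC)NC(=O)C(CC(C)C)NC(=O)OCc1ccccc1` gives 19 nM in an assay on isolated protein (Oryctolagus cuniculus) for inhibition of Calpain-2 catalytic subunit (Homo sapiens), at pH 8.0 (on this read-out lower numbers stand for stronger inhibition and higher numbers for weaker inhibition), the lowest of the three numbers measured so far: compound 2 `CCC(NC(=O)C(CC(C)C)NC(=O)OCc1ccccc1)C(=O)C(=O)NCC1CCCCC1` gives 44 nM and compound 1 `CCC(NC(=O)C(CC(C)C)NC(=O)OCc1ccccc1)C(=O)C(=O)NCC(C)C` gives 140 nM. The steps of a 7.4-fold lower number from compound 1 to compound 3 (0.87 log units; beyond the scatter) and a 2.3-fold lower number from compound 2 to compound 3 (0.36 log units; beyond the scatter) both ran toward the longer chain. Compound 4 `CCC(NC(=O)C(CC(C)C)NC(=O)OCc1ccccc1)C(=O)C(=O)NCCCc1ccccc1` differs from compound 3 by phenyl in place of pentyl on a saturated chain carbon, three bonds along the chain from an amide-type nitrogen, so its tail keeps a comparable length but ends in a ring rather than a chain. Because a 2.3-fold lower number from compound 2 to compound 3 (0.36 log units; beyond the scatter) was only modest, the expected step is a 1.5-fold higher number from compound 3 to compound 4 (0.17 log units; within the scatter), a small weakening that may not exceed the scatter. Compound 4 is therefore estimated at 28 nM, with a range from 9 nM to 90 nM.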

Compound 4, inhibition constant: 43 nM
For compound 4 the middle estimate is 1.5-fold (0.19 log units) below the measured one, and the stated range covers the measured number.
By their numbers in this assay, from the lowest: compound 3; then compounds 4 and 2 (each within the scatter of the next); then compound 1.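

Swapping octyl for 3-phenylpropyl at this tail costs a little (a 2.3-fold higher number from compound 3 to compound 4 (0.35 log units; beyond the scatter)), so a ring at the chain end does not match the open chain. Yet phenethyl in place of cyclohexyl leaves the two compounds indistinguishable (a 1.0-fold lower number from compound 2 to compound 4 (0.01 log units; within the scatter)), and phenethyl in place of isopropyl still gives a clear improvement (a 3.3-fold lower number from compound 1 to compound 4 (0.51 log units; beyond the scatter)). Nothing available explains these differences.

Still open, as far as these compounds go, is whether a longer chain ending in phenyl would recover the loss. Also open, from the compounds shown here alone, is how a pyridine ring or a terminal amine would fare at this position.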